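A few compounds are considered here, and "the series" means these few. Any claim that something is new, unique, unknown or untested is made for them only; others in the source may bear on it.

Compound 1 (`COc1cc(Cl)c(-c2nc(SCC(=O)NC3CC3)nc3[nH]cc(C#N)c23)cc1OC`) gives 60 nM in a functional assay on HCT-116 cells (Homo sapiens) for antiproliferative activity, read by sulforhodamine B assay, with a stated time of 4 days; a higher number here means a weaker inhibitor of growth, a lower number a stronger inhibitor of growth
Compound 2 (`CCNC(=O)CSc1nc(-c2cc(OCC)c(OC)cc2Cl)c2c(C#N)c[nH]c2n1`) gives 40 nM in this assay

Compound 1 at 60 nM and compound 2 at 40 nM lie within the usual scatter of each other, so the numbers do not place either one ahead. Compound 3 (`COc1cc(Cl)c(-c2nc(SCC(=O)NC(C)C)nc3[nH]cc(C#N)c23)cc1OC`) has not yet been measured. It keeps the core of compound 1 with one change: isopropyl in place of cyclopropyl on an amide-type nitrogen. Among the measured compounds shown here, no measured pair shows this change on its own, and compound 2 differs from compound 1 in more than one place, so the data give no direct size for it. For the measured compounds named here, the only guide is that compound 2 at 40 nM stays within the scatter of compound 1 despite those differences. On that basis no step beyond the scatter is expected in this assay in either direction. The expected move is no change at the digits printed from compound 1 to compound 3 (within the scatter) and should stay inside the scatter. For compound 3 the estimated value is 60 nM with an expected range from 25 nM to 140 nM once it is measured.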

Compound 3, concentration for 50% growth inhibition: 81 nM
Compound 3: middle estimate off by 1.4-fold (0.13 log units), on the low side; the range from low to high includes it.
By their numbers in this assay, from the lowest: compounds 2, 1 and 3 (each within the scatter of the next, the first and the last beyond it).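

In this assay, among the compounds shown here, replacing cyclopropyl with isopropyl on the amide-type nitrogen gives a 1.4-fold higher number from compound 1 to compound 3 (0.13 log units; within the scatter), the first reading of this change on its own, since compound 2 differs from compound 1 in more than one place. On the core of compound 1, this open-chain group with the same count of carbon atoms stays within the scatter, so for this pair the three-membered ring is not needed to keep the value in this range. No measurement bears on why the two groups read alike in this assay, and the result says nothing about the mechanism behind it.

The amide nitrogen carries only cyclopropyl, isopropyl or ethyl in the compounds shown, all groups of carbon alone, so it remains open whether a phenyl ring, a longer chain, or a chain ending in an amine or a carboxylic acid would be tolerated there. Also open, on these data alone, is what ethyl alone would do on the core of compound 1, and whether the cyclopropyl and isopropyl groups would read alike on a core other than that of compound 1.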